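From 3-hydroxyphenyl to 4-hydroxyphenyl on the shared core

The compounds below may be only part of what the source reports. "The series", "measured", "known", "first", "only" and "open" are said of these compounds alone.

In an ADME assay on microsomes from liver (Rattus norvegicus) for metabolic stability, read by LC-MS, using NADPH, with stated times of 5 min and 60 min, tested at 4 uM (a lower number here means that less of the compound is left, a higher number that more of the compound is left), compound 1 `CC1=C(c2nc(-c3ccc(C#N)cc3)cs2)C(c2cc3ccccc3n2C)NC(=O)N1` gives 62.9%, compound 2 `CC1=C(c2nc(-c3ccc(C#N)cc3)cs2)C(c2ccc(F)nc2)NC(=O)N1` gives 49.4% and compound 3 `CC1=C(c2nc(-c3ccc(C#N)cc3)cs2)C(c2cccc(O)c2)NC(=O)N1` gives 52.4%. Thus a number 3 percentage points higher from compound 2 to compound 3 (within the scatter) places compound 3 level with its nearest neighbour, whereas a number 10.5 percentage points lower from compound 1 to compound 3 (beyond the scatter) separates it from the highest number. Compound 4 `CC1=C(c2nc(-c3ccc(C#N)cc3)cs2)C(c2ccc(O)cc2)NC(=O)N1` is related through (4-hydroxyphenyl in place of 3-hydroxyphenyl on a saturated ring carbon). The nearest evidence is weak, since a number 10.5 percentage points lower from compound 1 to compound 3 (beyond the scatter) and a number 13.5 percentage points lower from compound 1 to compound 2 (beyond the scatter) both replace a different group, and a number 3 percentage points higher from compound 2 to compound 3 (within the scatter) stays within the scatter. For the measured compounds named here, no measured pair compares these two hydroxyphenyl groups directly, so no step beyond the scatter is expected in this assay. The expected step is a number 2.4 percentage points lower from compound 3 to compound 4 (within the scatter). Compound 4 is therefore estimated at 50%, with an expected range of 37% to 64%.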

Compound 4, percent of the compound remaining: 100%
Beside the measured number, compound 4's estimate is 50 percentage points below it, and the stated range ends below it.
By their numbers in this assay, from the lowest: compounds 2 and 3 (each within the scatter of the next); then compound 1; then compound 4.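

In this assay, the place of the hydroxyl group on the phenyl ring matters greatly: the two groups have the same atoms, yet a number 47.6 percentage points higher from compound 3 to compound 4 (beyond the scatter). For the compounds shown here, the 4-hydroxyphenyl group also stands well clear of the other two groups, with a number 50.6 percentage points higher from compound 2 to compound 4 (beyond the scatter) and a number 37.1 percentage points higher from compound 1 to compound 4 (beyond the scatter), a size of change that the earlier steps at this carbon gave no hint of. No measurement at hand explains this difference. Still open, going by these compounds, is whether 4-methoxyphenyl or 4-aminophenyl at this carbon would give a similar number, which would show how much depends on the hydroxyl group itself.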